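Halogen swap on the aryl sulfonyl group of compound 1

The source may hold more compounds than are shown below. What is called first, only, known or untested is meant among the compounds shown, and "the series" means these compounds.

Among the measured compounds shown here, two measured compounds make up the series so far. Compound 1 `O=C(O)CCC/C=C\C[C@H]1/C(=N/OCC2CCCCC2)CC[C@@H]1NS(=O)(=O)c1ccc(F)cc1` gives 1800 nM in a functional assay (plasma) for inhibition, with Homo sapiens as the target (a higher number here means a weaker inhibitor, a lower number a stronger inhibitor), the highest of the two numbers in hand. For the measured compounds named here, compound 2 `O=C(O)CCC/C=C\C[C@H]1C(=O)CC[C@@H]1NS(=O)(=O)c1ccc(F)cc1` gives 500 nM in this assay; the two compounds differ in more than one place, so their values show only that compound 2 sits lower, by a gap beyond the scatter. Compound 3 `O=C(O)CCC/C=C\C[C@H]1/C(=N/OCC2CCCCC2)CC[C@@H]1NS(=O)(=O)c1ccc(Cl)cc1` is not yet measured. It differs from compound 1 in one place: chloro in place of fluoro on an aromatic carbon. Going by the values given here, no pair of measured compounds differs by this change alone, so nothing in hand bears on its size. The change is expected to give a step in this assay that is small, of either sign, and most likely within the scatter. Compound 3 is therefore estimated at 1400 nM, with a range of 600 nM to 3500 nM, which amounts to an expected step of a 1.3-fold lower number from compound 1 to compound 3 (0.11 log units; within the scatter).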

Compound 3, half-maximal inhibitory concentration: 1700 nM
Beside the measured number, compound 3's estimate is 1.2-fold (0.08 log units) below it; the measured number falls inside the stated range.
By their numbers in this assay, from the lowest: compound 2; then compounds 3 and 1 (each within the scatter of the next).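

In this assay, among the compounds shown here, chloro in place of fluoro on the aromatic carbon para to a large group gives a 1.1-fold lower number from compound 1 to compound 3 (0.02 log units; within the scatter), the only step that isolates a single place. On the core of compound 1, this assay therefore does not tell these two halogens apart at this position, which the earlier comparison of compound 1 and compound 2 could not show. No separate measurement bearing on this result is in hand.

From the compounds shown here alone, it remains open whether a bromo, methoxy, nitrile or amine group at the same place would also stay within the scatter of compound 1. Going by these compounds, it also remains open whether the same halogen swap gives a similar step on the core of compound 2, which carries a carbonyl in place of the oxime ether.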